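Para-alkyl series: isopropyl to tert-butyl on the aniline ring

The compounds below may be only part of what the source reports. "The series", "measured", "known", "first", "only" and "open" are said of these compounds alone.

Going by the values given here, compound 1 `CC(C)c1ccc(N2C(=O)C=CC2OCC(F)(F)F)cc1` gives 6620 nM in a functional assay on K562 cells (Homo sapiens) for inhibition (on this read-out lower numbers stand for stronger inhibition and higher numbers for weaker inhibition), the lowest of the three numbers so far, though neither of its companions lies beyond the scatter from it. Compound 3 `Cc1ccc(N2C(=O)C=CC2OCC(F)(F)F)cc1` gives 7140 nM in this assay, and the step of a 1.1-fold higher number from compound 1 to compound 3 (0.03 log units; within the scatter) is within the scatter. Among the compounds with values here, compound 2 `CC(C)NC1CC(=O)N(c2ccc(F)c(Cl)c2)C1OCC(F)(F)F`, built on a different core, gives 10500 nM in this assay; its value and that of compound 1 are within the scatter of each other, and no single-point step connects them.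

Compound 4 `CC(C)(C)c1ccc(N2C(=O)C=CC2OCC(F)(F)F)cc1` differs from compound 1 by methyl in place of hydrogen on a saturated chain carbon bound to an aromatic carbon and two saturated chain carbons. Within the data shown here, the only measured step that bears on it is a 1.1-fold higher number from compound 1 to compound 3 (0.03 log units; within the scatter), which altered the same alkyl group on the same aromatic carbon and moved the number by less than the scatter. Extending the branch one carbon further is therefore expected to give a step of a 1.0-fold lower number from compound 1 to compound 4 (0.01 log units; within the scatter) that stays within the scatter. For compound 4 the estimate in this assay is 6500 nM, with a range from 3000 nM to 14000 nM.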

Compound 4, half-maximal inhibitory concentration: 70 nM
Beside the measured number, compound 4's estimate is 93-fold (1.97 log units) above it; the measured number lies below the stated range.
By their numbers in this assay, from the lowest: compound 4; then compounds 1, 3 and 2 (each within the scatter of the next).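

The read-out on this aromatic carbon does not follow alkyl size in a graded way: in this assay methyl and isopropyl stay within the scatter of each other (a 1.1-fold higher number from compound 1 to compound 3 (0.03 log units; within the scatter)), yet tert-butyl gives a large drop (a 95-fold lower number from compound 1 to compound 4 (1.98 log units; beyond the scatter)) and an equally large one from the methyl compound (a 100-fold lower number from compound 3 to compound 4 (2.01 log units; beyond the scatter)). A single added methyl, turning isopropyl into tert-butyl, therefore separates compound 4 from every other compound shown, with all its steps printed beyond the scatter. No measurement offered here accounts for the size of this jump.

The compounds shown leave open whether the low number is specific to tert-butyl or would also appear with a cyclopropyl, a trifluoromethyl or a longer chain such as n-butyl at this carbon. They also leave open whether tert-butyl would give a similar drop on the core of compound 2.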